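The source may report more compounds than this note shows. Statements on the series, on what has been measured and on what is new or still open speak of the compounds shown alone.

Compound 1 `CC(C)(Oc1ccccc1)C1OCC(C/C=C\CCC(=O)O)C(c2cccnc2)O1`: 75000 nM
Compound 2 `COc1ccc(OC(C)(C)C2OCC(C/C=C\CCC(=O)O)C(c3cccnc3)O2)cc1`: > 100000 nM
Compound 3 `CC(C)(Oc1ccccc1[N+](=O)[O-])C1OCC(C/C=C\CCC(=O)O)C(c2cccnc2)O1`: < 1000 nM

In an assay for inhibition of prostacyclin synthase (Homo sapiens), using microsomes (a higher number here means a weaker inhibitor, a lower number a stronger inhibitor), compound 1 gives 75000 nM. The value of compound 2 is a limit of the assay, (the limit of > 100000 nM in this assay, at which 1 of the 3 values shown sits). The value of compound 3 is likewise a limit, (the limit of < 1000 nM in this assay, at which 1 of the 3 values shown sits). The change methoxy in place of hydrogen on an aromatic carbon made an at least 1.3-fold higher number from compound 1 to compound 2 (0.12 log units; that floor lies within the scatter). The cores of compound 1 and compound 3 differ by nitro in place of hydrogen on an aromatic carbon. That difference made an at least 75-fold lower number from compound 1 to compound 3 (1.87 log units; beyond the scatter), and a further computed step reads an at least 100-fold lower number from compound 2 to compound 3 (2.00 log units; beyond the scatter). Compound 4 `COc1ccc(OC(C)(C)C2OCC(C/C=C\CCC(=O)O)C(c3cccnc3)O2)c([N+](=O)[O-])c1` is not yet measured; it carries the same kind of change, (methoxy in place of hydrogen on an aromatic carbon), the place now being meta to a nitro group (3 heavy atoms) as well as para to a large group. A step of a number no lower from compound 3 to compound 4 (the limit leaves the size open) is expected, resting on an at least 1.3-fold higher number from compound 1 to compound 2 (0.12 log units; that floor lies within the scatter). Compound 4 is therefore estimated at 1000 nM, between 250 nM and 4000 nM.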

Compound 4, half-maximal inhibitory concentration: 23000 nM
For compound 4 the middle estimate is 23-fold (1.36 log units) below the measured one, outside the stated range (above it).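

In this assay, methoxy in place of hydrogen made an at least 23-fold higher number from compound 3 to compound 4 (1.36 log units; beyond the scatter), nitro in place of hydrogen made an at least 4.3-fold lower number from compound 2 to compound 4 (0.63 log units; beyond the scatter), and the two changes together made a 3.3-fold lower number from compound 1 to compound 4 (0.51 log units; beyond the scatter). The methoxy step is large on the nitro-bearing core, but this does not show that its size differs from that on the core of compound 1: the same change on two cores in this assay, an at least 1.3-fold higher number (0.12 log units; that floor lies within the scatter) from compound 1 to compound 2 and an at least 23-fold higher number (1.36 log units; beyond the scatter) from compound 3 to compound 4; the limit leaves it open whether they differ The nitro change lowered the number on both cores, but no fixed size for it is shown: the same change on two cores in this assay, an at least 75-fold lower number (1.87 log units; beyond the scatter) from compound 1 to compound 3 and an at least 4.3-fold lower number (0.63 log units; beyond the scatter) from compound 2 to compound 4; the limit leaves it open whether they differ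

As far as these compounds go, the true sizes of these steps stay open, as compound 2 and compound 3 each stand at a limit of the assay. Also open, from the compounds shown here alone, is how an amine or a nitrile in place of the nitro group would behave on either core.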